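A few compounds are considered here, and "the series" means these few. Any claim that something is new, unique, unknown or untested is made for them only; others in the source may bear on it.

Compound 1, `CCCCCCOc1ccc(-n2cnnc2C)cc1`, in a functional assay on the whole organism (strain C57B/6) with Mus musculus as the target, in the maximal electroshock model (on this read-out lower numbers stand for an effect already at smaller amounts and higher numbers for an effect only at larger amounts of compound), gives 22.8 mg/kg.
Compound 2, `CCCCCCCCCc1nncn1-c1ccc(OCCCCCC)cc1`, in this assay gives > 40 mg/kg, which is a limit of the assay and not a number.

Compound 2 stands at that limit, the top of what the assay reports, as described in the limit of > 40 mg/kg in this assay, at which 1 of the 2 values shown sits. Going by the values given here, the one step measured so far, an at least 1.7-fold higher number from compound 1 to compound 2 (0.24 log units; that floor lies within the scatter), shows that attaching a long chain to the shared core moved the result from a number to the limit; how far beyond the limit compound 2 really lies is unknown. Compound 3, `CCCCCCOc1ccc(-n2cnnc2-c2ccccc2F)cc1`, differs from compound 2 by 2-fluorophenyl in place of nonyl on an aromatic carbon. Among the compounds with values here, this change bears on the measured step only in part: it removes the nonyl chain whose addition is what the step from compound 1 to compound 2 tracked, but it puts a 2-fluorophenyl in its place, for which there is no measured step. The expectation is therefore a return toward the range of compound 1 rather than a stay at the limit, with wide uncertainty. Compound 3 is estimated at 28 mg/kg, between 10 mg/kg and 80 mg/kg, meaning an expected step of an at least 1.4-fold lower number from compound 2 to compound 3 (0.15 log units; that floor lies within the scatter).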

Compound 3, dose for half-maximal effect: 20.2 mg/kg
Estimate against measurement, compound 3: 1.4-fold (0.14 log units) above, within the range that was stated.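

The position on the shared core that carries methyl in compound 1 also takes a whole aromatic ring with no loss that can be read in this assay: the exchange of methyl for 2-fluorophenyl gives a 1.1-fold lower number from compound 1 to compound 3 (0.05 log units; within the scatter), so the two compounds cannot be told apart on this read-out. The exchange of the long chain for the ring gives an at least 1.9-fold lower number from compound 2 to compound 3 (0.29 log units; that floor lies within the scatter), which means that a large group at this position can still come with a measured number, and that the two large groups seen so far, nonyl and 2-fluorophenyl, are not yet separated beyond the scatter. For compound 2 the reading is a limit and not a number, and the step from it gives only a floor: the limit of > 40 mg/kg in this assay, at which 1 of the 3 values shown sits.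

Going by these compounds, whether the ring or its fluorine matters more stays open, and a plain phenyl, a shorter chain such as butyl, an amine or a carboxylic acid at this position would help to separate the two. On these data alone, how far compound 2 really lies from compound 3 also stays open, and with it whether chain and ring differ at all here.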